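Furanylmethyl in place of cyclopropylmethyl on the pyrrolidine nitrogen

The source may hold more compounds than are shown below. What is called first, only, known or untested is meant among the compounds shown, and "the series" means these compounds.

The two measured compounds share one core and differ only at the ring amine nitrogen of the pyrrolidine. Compound 1 `CN(C(=O)N1CC[C@H](n2cnc3cc(-c4ccc(Cl)cc4)sc3c2=O)C1)[C@H]1CCNC1` carries a hydrogen there, and in an assay on isolated protein for binding affinity to melanin-concentrating hormone receptor 1 (Homo sapiens) (on this read-out lower numbers stand for stronger inhibition and higher numbers for weaker inhibition), compound 1 gives 17 nM. Compound 2 `CN(C(=O)N1CC[C@H](n2cnc3cc(-c4ccc(Cl)cc4)sc3c2=O)C1)[C@H]1CCN(CC2CC2)C1` carries a cyclopropylmethyl group, and in this assay compound 2 gives 3 nM. For the measured compounds named here, the step of a 5.7-fold lower number from compound 1 to compound 2 (0.75 log units; beyond the scatter) is the only one available, and it leaves compound 2 with the lowest of the two numbers so far.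

Compound 3 `CN(C(=O)N1CC[C@H](n2cnc3cc(-c4ccc(Cl)cc4)sc3c2=O)C1)[C@H]1CCN(Cc2ccoc2)C1` keeps that substituted nitrogen but changes the group on it: furan-3-yl in place of cyclopropyl on a saturated chain carbon bound to an amine nitrogen in a ring. Going by the values given here, no measured step bears directly on this exchange; the single step from compound 1 to compound 2 speaks only to the gain from adding a group to the nitrogen, not to swapping one group for another of roughly similar size. With nothing beyond that to go on, compound 3 is expected to land close to compound 2 in this assay, with the step of a 1.7-fold higher number from compound 2 to compound 3 (0.22 log units; within the scatter) expected to stay within the scatter. The estimated value for compound 3 is therefore 5 nM, with a range from 1.5 nM to 15 nM.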

Compound 3, inhibition constant: 4 nM
For compound 3 the middle estimate is 1.3-fold (0.10 log units) above the measured one, within the range that was stated.
By their numbers in this assay, from the lowest: compounds 2 and 3 (each within the scatter of the next); then compound 1.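

In this assay the exchange of cyclopropyl for furan-3-yl on a saturated chain carbon bound to an amine nitrogen in a ring gives a 1.3-fold higher number from compound 2 to compound 3 (0.12 log units; within the scatter) and so does not separate the two groups, although the entering group brings a five-membered aromatic ring, more heavy atoms and a hydrogen-bond acceptor. The gain over the hydrogen on this nitrogen no longer rests on cyclopropylmethyl alone: a 4.3-fold lower number from compound 1 to compound 3 (0.63 log units; beyond the scatter) now stands with a 5.7-fold lower number from compound 1 to compound 2 (0.75 log units; beyond the scatter) and both lie beyond the scatter, so two different groups on this nitrogen give lower numbers than the hydrogen. There is no evidence at hand that accounts for this result.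

The compounds shown leave open how far this tolerance extends, since only cyclopropylmethyl and (furan-3-yl)methyl appear on the nitrogen. Whether a benzyl group, a furan-2-ylmethyl group, a longer chain such as n-butyl or a chain ending in a carboxylic acid would stay in the same range as compound 2 and compound 3 cannot be told from these data.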